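One Group Changed on a Carbonyl Carbon

The source may hold more compounds than are shown below. What is called first, only, known or untested is meant among the compounds shown, and "the series" means these compounds.

Compounds in this series share one core and differ in the group on a carbonyl carbon. Going by the values given here, in an in vivo ADME assay on the whole organism (strain CD-1) for metabolic stability, with Mus musculus as the target, at a dose of 2.5 mg/kg by the intravenous route (a higher number here means that the compound lasts longer, a lower number that the compound disappears faster), compound 1 `COc1cc(N2CCC(CC(=O)N3CCOCC3)CC2)ccc1Nc1nc(NC2CCCCC2)c2nc[nH]c2n1` gives 0.9 h, while compound 2 `COc1cc(N2CCC(CC(=O)N3CCN(C)CC3)CC2)ccc1Nc1nc(NC2CCCCC2)c2nc[nH]c2n1` gives 2.8 h, the higher of the two numbers so far. Compound 3 `COc1cc(N2CCC(CC(=O)N3CCCC3)CC2)ccc1Nc1nc(NC2CCCCC2)c2nc[nH]c2n1` has not yet been measured. It carries pyrrolidin-1-yl in place of 4-methylpiperazin-1-yl on a carbonyl carbon. Among the compounds with values here, only one measured step bears on this change: a 3.1-fold higher number from compound 1 to compound 2 (0.49 log units; beyond the scatter), a modest step beyond the usual scatter, with 4-methylpiperazin-1-yl in place of morpholin-4-yl. Compound 3 also lacks 4-methylpiperazin-1-yl, but it carries a different group from compound 1, so this single step is only a loose guide, and two values establish no rule. Going by that step, a fall in this assay is expected, somewhat smaller than the rise seen there: the expected change is a 2.2-fold lower number from compound 2 to compound 3 (0.33 log units; beyond the scatter). For compound 3, the estimated half-life is 1.3 h, with an expected range of 0.6 h to 2.8 h.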

Compound 3, half-life: 2 h
Compound 3: middle estimate off by 1.5-fold (0.19 log units), on the low side, and the stated range covers the measured number.
By their numbers in this assay, from the lowest: compound 1; then compounds 3 and 2 (each within the scatter of the next).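

In this assay the new step is small (a 1.4-fold lower number from compound 2 to compound 3 (0.15 log units; within the scatter)), so pyrrolidin-1-yl and 4-methylpiperazin-1-yl cannot be told apart on the carbonyl carbon, even though the two groups differ in ring size and in their hetero atoms. Measured against morpholin-4-yl, the new group does make a difference (a 2.2-fold higher number from compound 1 to compound 3 (0.35 log units; beyond the scatter)), which shows that a longer half-life than that of compound 1 is not tied to 4-methylpiperazin-1-yl alone. Among these three compounds, then, compound 1 with its morpholin-4-yl is the one that stands apart, while compound 2 and compound 3 sit together within the usual scatter.

The data offer no measured explanation for why morpholin-4-yl stands apart from the other two groups. On these data alone, it also remains open whether a six-membered piperidin-1-yl ring or an open-chain dimethylamino group on the same carbonyl carbon would sit with compound 2 and compound 3 or with compound 1, and whether a piperazine ring bearing a hydrogen instead of the methyl group would stay with compound 2.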